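The source may report more compounds than this note shows. Statements on the series, on what has been measured and on what is new or still open speak of the compounds shown alone.

Measured compounds:
Compound 1, `CN(Cc1ccccc1)C(=O)c1nc(Cc2ccccc2C(F)(F)F)n(C)c(=O)c1O`, gives > 100000 nM in an ADME assay on HepG2 cells (Homo sapiens) for cytotoxicity, in the presence of a further agent that is not named here (on this read-out higher numbers stand for weaker inhibition and lower numbers for stronger inhibition), which is a limit of the assay and not a number.
Compound 2, `COc1c(C(=O)NCc2ccccc2)nc(Cc2ccccc2C(F)(F)F)n(C)c1=O`, gives > 100000 nM in this assay, again a limit of the assay.

Compound 1 therefore stands at the limit, and nothing in the numbers sets it apart from compound 2, because of the limit of > 100000 nM in this assay, at which 2 of the 2 values shown sit. With only limits in hand, no step between measured compounds can be sized, and no cause for their behaviour can be read off.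

Compound 3, `CC(NC(=O)c1nc(Cc2ccccc2C(F)(F)F)n(C)c(=O)c1O)c1ccccc1`, is built from the same atoms as compound 1, joined differently: (1-phenylethyl)amino in place of benzyl(methyl)amino on a carbonyl carbon. Compound 1 and compound 2 both sit at the limit, so the step from compound 1 to compound 3 in this assay is expected to be none beyond the scatter, that is a number no higher from compound 1 to compound 3 (the limit leaves the size open). Compound 3 is accordingly estimated at 100000 nM, within 30000 nM to 300000 nM, most likely again only a limit.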

Compound 3, half-maximal inhibitory concentration: > 100000 nM
Compound 3: a limit, no number (the forecaster's own chance of this, stated with the estimate: 85%); the middle value lies on the limit itself.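

For the compounds shown here, no step from compound 1 to compound 3 can be read, because each gives only a limit of the assay and not a number: the limit of > 100000 nM in this assay, at which 3 of the 3 values shown sit. The compounds shown leave open in this assay whether (1-phenylethyl)amino in place of benzyl(methyl)amino changes the result at all.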